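An Ester Gives Way to an Amide

A few compounds are considered here, and "the series" means these few. Any claim that something is new, unique, unknown or untested is made for them only; others in the source may bear on it.

Within the data shown here, compound 1 `O=C(OC(CCCN1CCN(c2ncc(F)cn2)CC1)c1ccc(F)cc1)c1ccccc1` is the only compound here with a number. In an assay (Cavia porcellus) for displacement of a labelled ligand from Sigma non-opioid intracellular receptor 1 (Homo sapiens) (a lower number here means a stronger inhibitor, a higher number a weaker inhibitor), compound 1 gives 3500 nM, while compound 2 `Fc1cnc(N2CCN(CCCCC3CCCCC3)CC2)nc1` in this assay shows no result reported, so nothing can be said of it. Compound 3 `O=C(NC(CCCN1CCN(c2ncc(F)cn2)CC1)c1ccc(F)cc1)c1ccc(F)cc1` differs from compound 1 in one place: ((4-fluorophenyl)carbonyl)amino in place of benzoyloxy on a saturated chain carbon bound to an aromatic carbon and a saturated chain carbon. Among the measured compounds shown here, no measured pair shows what such a change does, so the expected step is small and uncertain, leaning slightly toward stronger binding but possibly not beyond the scatter. Compound 3 is therefore expected to give 2000 nM, with a range from 500 nM to 8000 nM, an expected step of a 1.8-fold lower number from compound 1 to compound 3 (0.24 log units; within the scatter).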

Compound 3, half-maximal inhibitory concentration: > 100 nM
Compound 3 gave a limit, no number; the forecaster's own chance of this, stated with the estimate: 10%; the middle value does not contradict the limit.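

Among these compounds, compound 3 gave only the limit > 100 nM and not a number, and no step from compound 1 to compound 3 can be read. As far as these compounds go, whether ((4-fluorophenyl)carbonyl)amino in place of benzoyloxy strengthens or weakens binding stays open.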